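A few compounds are considered here, and "the series" means these few. Any claim that something is new, unique, unknown or untested is made for them only; others in the source may bear on it.

Measured compounds:
- compound 1, `O=C(Nc1ccc(F)cc1)Nc1cc(F)cc(Oc2cccnc2)c1`; 1.1 ug/mL in a physicochemical assay for solubility, measured as kinetic solubility; a higher number here means a more soluble compound, a lower number a less soluble compound
- compound 2, `COc1ccc(NC(=O)Nc2cc(F)cc(Oc3cccnc3)c2)cc1`; < 1 ug/mL in this assay

Compound 2 stands at the floor of the series: in this assay compound 2 returns only a limit, < 1 ug/mL, so its true value is not known. Among the compounds with values here, the single measured step, an at least 1.1-fold lower number from compound 1 to compound 2 (0.04 log units; that floor lies within the scatter), is bounded by that limit of < 1 ug/mL in this assay, at which 1 of the 2 values shown sits, and adds nothing that can be read as a trend.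

Compound 3, `COc1ccc(NC(=O)Nc2cc(F)cc(Oc3cccnc3)c2)cn1`, differs from compound 2 by 6-methoxypyridin-3-yl in place of 4-methoxyphenyl on an amide-type nitrogen. Within the data shown here, no measured step covers this exchange; the step from compound 1 to compound 2 concerns a different position and a different group, so it bears only indirectly. Against a starting point that is itself a limit, the expectation for compound 3 is a step of an at least 2.0-fold higher number from compound 2 to compound 3 (0.30 log units; that floor lies within the scatter) in this assay, upward if anything, with a fair chance that compound 3 again returns only a limit. The estimate for compound 3 is 2 ug/mL, within 0.7 ug/mL to 6 ug/mL.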

Compound 3, solubility: 28 ug/mL
For compound 3 the middle estimate is 14-fold (1.15 log units) below the measured one; measured number outside the range, above it.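

Within the data shown here, on the amide-type nitrogen, the identity of the aromatic ring carries far more weight in this assay than the earlier compounds could show: 6-methoxypyridin-3-yl in place of 4-methoxyphenyl gives an at least 28-fold higher number from compound 2 to compound 3 (1.44 log units; beyond the scatter), with the methoxy group kept and the heavy-atom count unchanged. The same group in place of 4-fluorophenyl gives a 25-fold higher number from compound 1 to compound 3 (1.41 log units; beyond the scatter), so compound 3 stands clear of both compounds with a six-membered aromatic ring of carbon only. The step from compound 2 is a floor and not a full size: the limit of < 1 ug/mL in this assay, at which 1 of the 3 values shown sits.

Open, going by these compounds, is whether the methoxy group is needed, or whether a plain pyridin-3-yl, or a pyridine ring carrying an amine or a carboxylic acid, would hold the number. Compound 3 is also the only compound shown with this ring, so how far the step carries over to other cores remains unknown.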